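Adding a Methoxy Group to a Compound Read Only as a Limit

A few compounds are considered here, and "the series" means these few. Any claim that something is new, unique, unknown or untested is made for them only; others in the source may bear on it.

Of the compounds shown here, three sharing one core have been read in an ADME assay on HEK293 cells (Homo sapiens) for cytotoxicity, read by resazurin assay, with a stated time of 72 h (a higher number here means that more compound is tolerated, a lower number that less compound is tolerated), and none gives a number. Compound 1 (`CCc1ccccc1CNC(=O)c1nc2ccc(F)c(OCCc3ccc(C(=O)O)cc3)c2c(=O)[nH]1`) gives > 20000 nM, which is a limit. Compound 2 (`CCc1cccc(CNC(=O)c2nc3cccc(COc4ccc(C(=O)O)cc4)c3c(=O)[nH]2)c1`) gives > 20000 nM, also a limit. Compound 3 (`CCc1cccc(CNC(=O)c2nc3cccc(COCc4ccc(C(=O)O)cc4)c3c(=O)[nH]2)c1`) gives > 40000 nM, again only a limit. Among the measured compounds shown here, the one measured step, a step that the two limits leave unreadable from compound 2 to compound 3, puts 4-carboxybenzyl in place of 4-carboxyphenyl and offers no size to carry forward.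

Compound 4 (`CCc1cccc(CNC(=O)c2nc3ccc(OC)c(COCc4ccc(C(=O)O)cc4)c3c(=O)[nH]2)c1`) differs from compound 3 by one change, methoxy in place of hydrogen on an aromatic carbon, ortho to a ((4-carboxybenzyl)oxy)methyl group. For the measured compounds named here, no measured step involves a methoxy group. What bears on compound 4 is only (the limit of > 20000 nM in this assay, at which 2 of the 3 values shown sit), together with the limit of > 40000 nM in this assay, at which 1 of the 3 values shown sits. No step beyond the scatter is expected in this assay, and the assay will most likely report a limit again. The expected step is a number no higher from compound 3 to compound 4 (the limit leaves the size open). For compound 4 the estimate is 40000 nM, with an expected range of 15000 nM to 100000 nM.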

Compound 4, half-maximal cytotoxic concentration: > 20000 nM
Compound 4: only a limit was reported; the forecaster's own chance of this, stated with the estimate: 85%; the middle value lies beyond the limit too.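

In this assay compound 4 gives > 20000 nM, which is a limit. With compound 3 also read only as a limit, no step can be read between compound 3 and compound 4. The compounds shown leave open what size of change, if any, the methoxy group brings.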